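Chlorophenyl to Dimethoxyphenyl on the Sulfonyl Sulfur

The source may hold more compounds than are shown below. What is called first, only, known or untested is meant among the compounds shown, and "the series" means these compounds.

Of the compounds shown here, three sharing one core have been measured in a functional assay on HCT-116 cells (Homo sapiens) for antiproliferative activity, read by MTT assay, with a stated time of 72 h; on this read-out lower numbers stand for stronger inhibition and higher numbers for weaker inhibition. Compound 1 `CN(C(=O)c1ccc(F)cc1)c1ccc2[nH]c(-c3n[nH]c4ccccc34)cc2n1` gives 9270 nM; compound 2 `COc1ccc(C(=O)N(C)c2ccc3[nH]c(-c4n[nH]c5ccccc45)cc3n2)cc1` gives 29500 nM; compound 3 `CN(c1ccc2[nH]c(-c3n[nH]c4ccccc34)cc2n1)S(=O)(=O)c1ccc(Cl)cc1` gives 5980 nM. For the measured compounds named here, compound 3 thus holds the lowest of the three numbers, yet the step of a 1.6-fold lower number from compound 1 to compound 3 (0.19 log units; within the scatter) lies within the scatter, so compound 3 and compound 1 cannot be ordered against each other; only the step of a 4.9-fold lower number from compound 2 to compound 3 (0.69 log units; beyond the scatter) sets compound 2 clearly apart.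

Compound 4 `COc1ccc(S(=O)(=O)N(C)c2ccc3[nH]c(-c4n[nH]c5ccccc45)cc3n2)c(OC)c1` differs from compound 3 in one place: 2,4-dimethoxyphenyl in place of 4-chlorophenyl on a sulfonyl sulfur. Going by the values given here, two measured steps bear on this. Within the carbonyl pair, the step of a 3.2-fold higher number from compound 1 to compound 2 (0.50 log units; beyond the scatter) came with methoxy in place of fluoro on the aromatic ring. The step of a 4.9-fold lower number from compound 2 to compound 3 (0.69 log units; beyond the scatter) likewise ran from a methoxy-bearing aryl to a chloro-bearing one, and there the number fell. Both steps point toward higher numbers when methoxy groups take the place of a halogen on the aryl ring, and compound 4 carries two of them. Compound 4 is therefore expected to show a modestly higher number than compound 3, an estimated step of a 2.5-fold higher number from compound 3 to compound 4 (0.40 log units; beyond the scatter). The estimate for compound 4 is 15000 nM, with an expected range from 5000 nM to 45000 nM.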

Compound 4, half-maximal inhibitory concentration: 21800 nM
Estimate against measurement, compound 4: 1.5-fold (0.16 log units) below; measured number inside the range.
By their numbers in this assay, from the lowest: compounds 3 and 1 (each within the scatter of the next); then compounds 4 and 2 (each within the scatter of the next).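

In this assay, the position on the sulfonyl sulfur now has a step of its own, and it is beyond the scatter: a 3.6-fold higher number from compound 3 to compound 4 (0.56 log units; beyond the scatter), with the sulfonamide nitrogen and the shared core held fixed. For the compounds shown here, until now, a methoxy group replacing a halogen with the linking group unchanged had been seen only on the carbonyl side, in a 3.2-fold higher number from compound 1 to compound 2 (0.50 log units; beyond the scatter), so the same direction now appears in both the carbonyl and sulfonyl pairs, though each is a single pair. Nothing measured here accounts for this rise in the number.

The change removes the chlorine and brings in two methoxy groups at once, so the compounds shown leave open how much of the step belongs to losing the chlorine and how much to each methoxy group, a question that a plain phenyl or a 4-methoxyphenyl on the sulfonyl sulfur would help to separate. They also leave open whether an amine or a carboxylic acid on this aryl ring would bring the number below that of compound 3.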